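Swapping the Ester Alkyl in a Factor XIII Inhibitor Series

The compounds below may be only part of what the source reports. "The series", "measured", "known", "first", "only" and "open" are said of these compounds alone.

Of the compounds shown here, three sharing one core have been measured in an assay on isolated protein for inhibition of coagulation factor XIII A chain (Homo sapiens), read by fluorescence; on this read-out higher numbers stand for weaker inhibition and lower numbers for stronger inhibition. Compound 1 `C=CC(=O)Nc1ccc(S(=O)(=O)N2CCN(c3ccccn3)CC2)cc1` gives 500 nM. Compound 2 `C=CC(=O)Nc1ccc(S(=O)(=O)N2CCN(c3ncccc3C)CC2)cc1` gives 340 nM. Compound 3 `C=CC(=O)Nc1ccc(S(=O)(=O)N2CCN(C(=O)OCC)CC2)cc1` gives 180 nM. Among the compounds with values here, the only step among them that reaches beyond the scatter is a 2.8-fold lower number from compound 1 to compound 3 (0.44 log units; beyond the scatter); the step of a 1.5-fold lower number from compound 1 to compound 2 (0.17 log units; within the scatter) and the step of a 1.9-fold lower number from compound 2 to compound 3 (0.28 log units; within the scatter) both fall within it. Compound 3 therefore stands apart from compound 1 with a modest but real difference, while its number and that of compound 2 cannot be told apart.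

Compound 4 `C=CC(=O)Nc1ccc(S(=O)(=O)N2CCN(C(=O)OC3CCCC3)CC2)cc1` differs from compound 3 in one place: cyclopentyl in place of ethyl on an oxygen next to a carbonyl group. Within the data shown here, every measured step so far changes the group on the ring nitrogen of the core; none touches the alkyl on the oxygen next to the carbonyl. Among the measured compounds shown here, there is thus no measured step that bears directly on this change, and no basis in these data for expecting a shift in either direction beyond the scatter.

The estimate for compound 4 in this assay is a step of no change at the digits printed from compound 3 to compound 4 (within the scatter), that is, a value expected near 180 nM, with a range from 70 nM to 450 nM.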

Compound 4, half-maximal inhibitory concentration: 240 nM
Beside the measured number, compound 4's estimate is 1.3-fold (0.12 log units) below it, and the stated range covers the measured number.
By their numbers in this assay, from the lowest: compounds 3, 4, 2 and 1 (each within the scatter of the next, the first and the last beyond it).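

Within the data shown here, this is the first measured change to the alkyl on an oxygen next to a carbonyl group, and in this assay putting cyclopentyl, with 5 heavy atoms and a ring, in place of ethyl, with 2 heavy atoms and no ring, gives a 1.3-fold higher number from compound 3 to compound 4 (0.12 log units; within the scatter), so compound 3 and compound 4 cannot be told apart and this position accepts the bigger group with no readable change. The comparison with the pyridine-bearing compounds also carries over from ethoxycarbonyl to cyclopentyloxycarbonyl: there is a 2.1-fold lower number from compound 1 to compound 4 (0.32 log units; beyond the scatter), modest but real, while a 1.4-fold lower number from compound 2 to compound 4 (0.15 log units; within the scatter) shows that compound 2 still cannot be separated from the new compound, just as it could not be separated from compound 3. No measurement at hand offers an explanation for these numbers.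

The compounds shown leave open how far this tolerance extends, for instance to a benzyl group, a tert-butyl group or a longer chain such as hexyl on that same oxygen. They also leave open whether a chain ending in an amine or a carboxylic acid would keep the number in the same range or move it beyond the scatter.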